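The compounds below may be only part of what the source reports. "The series", "measured", "known", "first", "only" and "open" are said of these compounds alone.

In a physicochemical assay for solubility, at pH 6.8 (a higher number here means a more soluble compound, a lower number a less soluble compound), three related compounds have been tested so far. Compound 1 `CCCCOc1cccc(OCc2[nH]c3ccccc3c(=O)c2C)c1` gives < 1000 nM, which is a limit of the assay and not a number. Compound 2 `Cc1c(COc2cccc(OCC3CCOCC3)c2)[nH]c2ccc(C(=O)O)cc2c1=O` gives >= 100000 nM, which is also a limit. Going by the values given here, compound 3 `CC(C)c1c(COc2cccc(OCC3CCOCC3)c2)[nH]c2ccccc2c1=O` gives 3000 nM, the only actual number among the three. Compound 4 `Cc1c(COc2cccc(OCC3CCOCC3)c2)[nH]c2ccccc2c1=O` has not been measured, and it differs from compound 3 in one place: methyl in place of isopropyl on an aromatic carbon. Among the compounds with values here, no measured pair shows this change on its own, so the expectation is tentative: a modest rise in this assay, not far beyond the usual scatter. The estimated step is a 2.0-fold higher number from compound 3 to compound 4 (0.30 log units; within the scatter). The expected value for compound 4 is 6000 nM, with an estimated range of 1500 nM to 25000 nM.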

Compound 4, solubility: 5000 nM
Compound 4: middle estimate off by 1.2-fold (0.08 log units), on the high side; low and high end bracket the measured number.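

Methyl in place of isopropyl on this aromatic carbon gives a 1.7-fold higher number from compound 3 to compound 4 (0.22 log units; within the scatter), so in this assay the size of this group, across these two, makes no difference beyond the scatter. Hydrogen in place of carboxy gives an at least 20-fold lower number from compound 2 to compound 4 (1.30 log units; beyond the scatter), and oxan-4-yl in place of propyl gives an at least 5.0-fold higher number from compound 1 to compound 4 (0.69 log units; beyond the scatter). Both of these steps start from values that are limits of the assay and not numbers. Going by these compounds, what an amine or a longer chain would do on this same aromatic carbon stays open.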